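Second hydroxy on compound 2: expectation for compound 3

The source may hold more compounds than are shown below. What is called first, only, known or untested is meant among the compounds shown, and "the series" means these compounds.

Measured so far:
compound 1 `O=[N+]([O-])c1cccc(CSc2nnc(-c3ccncc3)n2-c2ccccc2)c1`: 18300 nM
compound 2 `O=C(CSc1nnc(-c2ccncc2)n1-c1ccccc1)N/N=C/c1ccc(O)cc1`: > 50000 nM

In a functional assay on MCF7 cells (Homo sapiens) for inhibition, read by MTT assay, with a stated time of 48 h (a higher number here means a weaker inhibitor, a lower number a stronger inhibitor), compound 1 gives 18300 nM. For compound 2 this assay reports only a limit, > 50000 nM, and no number. Compound 2 thus stands at the limit of > 50000 nM in this assay, at which 1 of the 2 values shown sits, the weaker end of what is shown; of the pair only this can be said, that compound 1 has a measured value and compound 2 does not.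

Compound 3 `O=C(CSc1nnc(-c2ccncc2)n1-c1ccccc1)N/N=C/c1ccc(O)c(O)c1` is not yet measured. It differs from compound 2 by hydroxy in place of hydrogen on an aromatic carbon, hydroxy entering ortho to a hydroxy group, meta to a large group. For the measured compounds named here, no step between measured compounds exists to guide the size of the change, and compound 2 itself offers only a limit. The step of a number no higher from compound 2 to compound 3 (the limit leaves the size open) is expected to stay within the usual scatter. Compound 3 is therefore estimated at 50000 nM, with a range from 20000 nM to 120000 nM, and this assay is likely to report a limit again.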

Compound 3, half-maximal inhibitory concentration: 19700 nM
The estimate for compound 3 lay 2.5-fold (0.40 log units) above the measured number, outside the stated range (below it).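

In this assay the change from 4-hydroxyphenyl to 3,4-dihydroxyphenyl gives an at least 2.5-fold lower number from compound 2 to compound 3 (0.40 log units; beyond the scatter), so the ring carbon ortho to a hydroxy group and meta to a large group is a place where hydroxy in place of hydrogen moves the read-out. Compound 3 gives 19700 nM, a measured number in this hydrazone subseries where compound 2 offered none. As far as these compounds go, the true size of the step remains open because the value for compound 2 is a limit and not a number: the limit of > 50000 nM in this assay, at which 1 of the 3 values shown sits.

The compounds shown leave open whether the step depends on the hydroxy group already on the ring. They also leave open whether a methoxy group, an amine or a fluorine atom entering at this place would shift the number in the same direction.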